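Cyclopropylcarbonyl to benzoyl on two related pyrazole cores

The compounds below may be only part of what the source reports. "The series", "measured", "known", "first", "only" and "open" are said of these compounds alone.

Measured compounds:
Compound 1 `CCCCNC(=O)N1Cc2c(NC(=O)c3ccc(C)cc3)nn(C(=O)C3CC3)c2C1`: 17600 nM
Compound 2 `CCCCNC(=O)N1Cc2c(NC(=O)c3ccc(C)cc3)nn(C(=O)c3ccccc3)c2C1`: 23200 nM
Compound 3 `O=C(Nc1nn(C(=O)C2CC2)c2c1CN(C(=O)c1ccccc1)C2)c1ccccc1`: 1240 nM

In a functional assay on HCT-116 cells (Homo sapiens) for cytotoxicity, read by sulforhodamine B assay, with a stated time of 48 h (on this read-out lower numbers stand for stronger inhibition and higher numbers for weaker inhibition), compound 3 gives the lowest number of the three, while compound 1 and compound 2 sit close to each other. The change from compound 1 to compound 2 is phenyl in place of cyclopropyl on a carbonyl carbon, and it makes a 1.3-fold higher number from compound 1 to compound 2 (0.12 log units; within the scatter). The same change is now carried onto compound 3 to give compound 4 `O=C(Nc1nn(C(=O)c2ccccc2)c2c1CN(C(=O)c1ccccc1)C2)c1ccccc1`: phenyl in place of cyclopropyl on a carbonyl carbon. The difference between the core of compound 1 and the core of compound 3 is not broken down here. Because the earlier step of a 1.3-fold higher number from compound 1 to compound 2 (0.12 log units; within the scatter) stayed within the scatter, the step from compound 3 to compound 4 in this assay is expected to be similarly small, about a 1.3-fold higher number from compound 3 to compound 4 (0.11 log units; within the scatter). Compound 4 is therefore estimated at 1600 nM, between 700 nM and 3800 nM.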

Compound 4, half-maximal inhibitory concentration: 1400 nM
Estimate against measurement, compound 4: 1.1-fold (0.06 log units) above, and the stated range covers the measured number.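

In this assay, cyclopropylcarbonyl to benzoyl gives a 1.1-fold higher number from compound 3 to compound 4 (0.05 log units; within the scatter). Set beside the earlier case, the two steps agree: the same change on two cores in this assay, a 1.3-fold higher number (0.12 log units; within the scatter) from compound 1 to compound 2 and a 1.1-fold higher number (0.05 log units; within the scatter) from compound 3 to compound 4, 1.2-fold (0.07 log units) apart, within the scatter of two such steps This shows that the change stays within the scatter on both cores in this read-out, but two pairs in a single cell assay do not show that it would behave the same way on any other core, or why it has so little effect here.

The compounds shown leave open whether an acetyl group or a longer acyl chain on that carbonyl carbon would also make so small a step. They also leave open whether a benzoyl carrying an amine or a carboxylic acid would do so.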